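The compounds below may be only part of what the source reports. "The series", "measured", "known", "first", "only" and "open" are said of these compounds alone.

Working notes on the series. Compound 1 `NS(=O)(=O)c1ccc(-n2nc(-c3ccc(Cl)cc3)cc2-c2cc(O)ccc2O)cc1` gives 50900 nM in a functional assay on cells (Cancer cell lines, Homo sapiens) for cytotoxicity, read by sulforhodamine B assay, with a stated time of 48 h; a higher number here means a weaker inhibitor of growth, a lower number a stronger inhibitor of growth. Compound 2 `Cc1ccc(-c2cc(C3=CC(=O)C=CC3=O)n(-c3ccc(S(N)(=O)=O)cc3)n2)cc1` gives 100000 nM in this assay, the higher of the two numbers shown, though the gap to compound 1 stays within the scatter. Compound 3 `NS(=O)(=O)c1ccc(-n2nc(-c3ccc(Cl)cc3)cc2C2=CC(=O)C=CC2=O)cc1` is not yet measured; it differs from compound 2 by chloro in place of methyl on an aromatic carbon. Among the measured compounds shown here, no measured pair shows this change, so the step from compound 2 to compound 3 is expected to be small, in no set direction, nothing beyond the scatter: a 1.3-fold lower number from compound 2 to compound 3 (0.10 log units; within the scatter). For compound 3 the estimate is 80000 nM, with a range of 35000 nM to 100000 nM.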

Compound 3, concentration for total growth inhibition: 65700 nM
The estimate for compound 3 lay 1.2-fold (0.09 log units) above the measured number; low and high end bracket the measured number.
By their numbers in this assay, from the lowest: compounds 1, 3 and 2 (each within the scatter of the next).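

Among the compounds shown here, on the 4-methylphenyl to 4-chlorophenyl change, this assay gives the first direct reading at this position (a 1.5-fold lower number from compound 2 to compound 3 (0.18 log units; within the scatter)), and chloro and methyl cannot be told apart here. For the compounds shown here, the first reading of the other single-place change, the six-membered non-aromatic ring group in place of the six-membered aromatic ring group on an aromatic carbon (a 1.3-fold higher number from compound 1 to compound 3 (0.11 log units; within the scatter)), also stays within the scatter. Nothing available bears on why these numbers sit so close.

Open, going by these compounds, is whether an amine or a carboxylic acid on that aromatic carbon would move the number beyond the scatter.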